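Cytotoxicity limits in the series, from compound 3 to compound 4

The compounds below may be only part of what the source reports. "The series", "measured", "known", "first", "only" and "open" are said of these compounds alone.

compound 1, `CCCCNc1nc(N)nc2ccn(Cc3ccsc3)c12`: in an ADME assay on HEK293 cells (Homo sapiens) for cytotoxicity, read by ATP content, with a stated time of 6 h (a lower number here means that less compound is tolerated, a higher number that more compound is tolerated), compound 1 gives > 24000 nM, a limit of the assay.
compound 2, `CCCCNc1nc(N)nc2ccn(Cc3cn4ccccc4n3)c12`: in this assay compound 2 gives > 24000 nM, also a limit.
compound 3, `CC(Nc1nc(N)nc2ccn(Cc3ccccn3)c12)c1ccccn1`: in this assay compound 3 gives > 24000 nM, again a limit.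

Compound 3 therefore stands where all three measured compounds stand, at the limit of > 24000 nM in this assay, at which 3 of the 3 values shown sit; no number separates them. Compound 4, `Cc1cc(CNc2nc(N)nc3ccn(Cc4ccccn4)c23)no1`, is the next one to be measured. It differs from compound 3 in one place: (5-methyl-1,2-oxazol-3-yl)methyl in place of 1-(pyridin-2-yl)ethyl on a nitrogen on an aromatic ring. Among the measured compounds shown here, no step between two measured compounds is available, so no measured size of change can be carried over. In this assay the expectation is no step beyond the scatter, the value of compound 4 being estimated to sit at the limit as well, so that a step that the limit leaves unreadable from compound 3 to compound 4 is expected to be flat. Compound 4 is thus estimated at 30000 nM, within 12000 nM to 100000 nM.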

Compound 4, half-maximal cytotoxic concentration: > 24000 nM
Compound 4 ended at the assay's limit (the forecaster's own chance of this, stated with the estimate: 85%); the middle value does not contradict the limit.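

The step from compound 3 to compound 4 cannot be read in this assay, as both values are limits of the assay: the limit of > 24000 nM in this assay, at which 4 of the 4 values shown sit.

The compounds shown leave open where the half-maximal cytotoxic concentration of any of them lies, and whether (5-methyl-1,2-oxazol-3-yl)methyl in place of 1-(pyridin-2-yl)ethyl changes it.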